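This account rests on a few compounds, and the source may have more. Where it says the series, first, only, none or still open, it means among the compounds named here.

Three compounds measured in a functional assay on THP-1 cells (Homo sapiens) for inhibition, read by sulforhodamine B assay, with a stated time of 48 h, tested at 50 uM (a higher number here means more inhibition of growth at the concentration tested, a lower number less inhibition of growth), frame the question. Compound 2 `COc1cc(/C=C/C(=O)/C=C/c2cc(OC)c(OC)c(OC)c2)ccc1OCc1cn(CCCOc2cc(=O)oc3ccccc23)nn1` gives 79%, the highest of the three numbers. Compound 1 `COc1ccc(/C=C/C(=O)/C=C/c2ccc(OCc3cn(CCCCCOc4cc(=O)oc5ccccc45)nn3)c(OC)c2)cc1` gives 39%, and compound 3 `COc1cc(/C=C/C(=O)/C=C/c2ccccc2)ccc1OCc1cn(CCCCCOc2cc(=O)oc3ccccc23)nn1` gives 26%; the gaps from compound 2 to both of these are beyond the scatter. Compound 1 and compound 2 differ in more than one place, so their two values are simply what they show.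

Compound 4 `COc1cccc(/C=C/C(=O)/C=C/c2ccc(OCc3cn(CCCOc4cc(=O)oc5ccccc45)nn3)c(OC)c2)c1` is not yet measured. It differs from compound 2 by 3-methoxyphenyl in place of 3,4,5-trimethoxyphenyl on a double-bonded chain carbon bound to a double-bonded chain carbon. For the measured compounds named here, the one measured step that bears on removing a methoxy group is a number 13 percentage points lower from compound 1 to compound 3 (beyond the scatter), a modest loss from a single such removal. Compound 4 loses two methoxy groups from the ring that carried three, so a larger fall than that single step is expected, though the step from compound 1 to compound 3 concerned a different chain length and is only a rough guide. The expected change is a number 27 percentage points lower from compound 2 to compound 4 (beyond the scatter). For compound 4 in this assay the estimate is 52%, with a range from 32% to 70%.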

Compound 4, percent growth inhibition at one concentration: 58%
Compound 4: the middle estimate sits 6 percentage points below what was measured; the measured number falls inside the stated range.
By their numbers in this assay, from the lowest: compound 3; then compound 1; then compound 4; then compound 2.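

Replacing 3,4,5-trimethoxyphenyl with 3-methoxyphenyl on a double-bonded chain carbon bound to a double-bonded chain carbon gives, in this assay, a number 21 percentage points lower from compound 2 to compound 4 (beyond the scatter) and is the only step shown at this position. It shows that the groups on this ring affect growth inhibition at the concentration tested, but the loss is partial: compound 4 still gives 58% with a single methoxy group left on the ring. No measurement here explains why the number falls with this change.

The step removes two methoxy groups at once, so the compounds shown leave open how much each removal contributes. Also open, as far as these compounds go, is how a hydroxyl group or a dimethylamino group on this ring would compare with methoxy.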